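The compounds below may be only part of what the source reports. "The series", "measured", "known", "first", "only" and "open" are said of these compounds alone.

In an ADME assay on microsomes from liver (Rattus norvegicus) for metabolic stability (on this read-out lower numbers stand for a shorter-lived compound and higher numbers for a longer-lived compound), compound 1 `CC#C[C@@H](Cc1nnn[nH]1)c1ccc(OCc2ccc3scc(-c4cc(OCCOC)ccc4C)c3c2)cc1` gives 0.367 h, compound 2 `CC#C[C@@H](Cc1nnn[nH]1)c1ccc(OCc2cc(Cl)c3scc(-c4ccccc4C)c3c2)cc1` gives 0.117 h and compound 3 `CC#C[C@@H](Cc1nnn[nH]1)c1ccc(OCc2ccc3sc(C)c(-c4ccc(OCCOC)cc4C)c3c2)cc1` gives 0.117 h. Compound 3 thus stands level with compound 2, and both lie below compound 1 by more than the usual scatter of repeated measurements. Compound 4 `CC#C[C@@H](Cc1nnn[nH]1)c1ccc(OCc2ccc3sc(C(F)(F)F)c(-c4ccc(OCCOC)cc4C)c3c2)cc1` differs from compound 3 in one place, with trifluoromethyl in place of methyl on an aromatic carbon. Among the measured compounds shown here, no two measured compounds differ in only one place, so the data offer no direct guide to this change. A modest upward move is expected, estimated as a 1.9-fold higher number from compound 3 to compound 4 (0.27 log units; within the scatter), about the size of the scatter. Compound 4 is estimated at 0.22 h, with an expected range from 0.09 h to 0.55 h.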

Compound 4, half-life: > 3 h
Compound 4 ended at the assay's limit (the forecaster's own chance of this, stated with the estimate: 5%); middle value at least 13-fold (1.13 log units) away from the limit.
By their numbers in this assay, from the lowest: compounds 2 and 3 (each within the scatter of the next); then compound 1. At a limit, above all of these: compound 4.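

On the aromatic carbon next to the ring sulfur, trifluoromethyl in place of methyl gives an at least 25-fold higher number from compound 3 to compound 4 (1.40 log units; beyond the scatter). Among the compounds shown here, this is the first view of a single change, and it shows that this one position can move the half-life a long way. In this assay compound 4 gives > 3 h, which is a limit of the assay and not a number: the limit of > 3 h in this assay, at which 1 of the 4 values shown sits.

From the compounds shown here alone, whether a nitrile or an ethyl group on this carbon would act the same way stays open. So does the question whether the change would hold on the other substitution patterns seen in compound 1 and compound 2.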